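The source may report more compounds than this note shows. Statements on the series, on what has been measured and on what is new or still open speak of the compounds shown alone.

Measured in a functional assay on A2780 cells (Homo sapiens) for antiproliferative activity, read by fluorescence, with a stated time of 72 h; a higher number here means a weaker inhibitor, a lower number a stronger inhibitor:
- compound 1 `CC(C)(C)C(=O)N1Cc2c(NC(=O)c3ccc(F)cc3)n[nH]c2C1(C)C`: 270 nM
- compound 2 `CCN1CCC(C(=O)N2Cc3c(NC(=O)CC(C)C)n[nH]c3C2(C)C)CC1`: 410 nM
- compound 3 `CN1CCN(C(=O)N2Cc3c(NC(=O)c4ccc(F)cc4)n[nH]c3C2(C)C)CC1`: 180 nM

In this assay, compound 3 at 180 nM lies within the scatter of compound 1 at 270 nM. Its number is lower, by more than the scatter, than that of compound 2 at 410 nM.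

The next compound, compound 4 `CCN1CCC(C(=O)N2Cc3c(NC(=O)c4ccc(F)cc4)n[nH]c3C2(C)C)CC1`, keeps everything in compound 3 except one group: 1-ethylpiperidin-4-yl takes the place of 4-methylpiperazin-1-yl on a carbonyl carbon, (1-ethylpiperidin-4-yl in place of 4-methylpiperazin-1-yl on a carbonyl carbon).

Within the data shown here, only one measured step changes the group at this place: a 1.5-fold lower number from compound 1 to compound 3 (0.18 log units; within the scatter). That swap of tert-butyl for 4-methylpiperazin-1-yl stayed within the scatter, so the group on this carbonyl carbon has so far shown little effect on the number. Among the measured compounds shown here, compound 2 also carries 1-ethylpiperidin-4-yl on a carbonyl carbon, but it differs from compound 4 elsewhere, so compound 2 at 410 nM gives only a loose hint, and no measured step isolates this group.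

No shift beyond the scatter is therefore expected in this assay, though a slightly higher number would not surprise. The expected change is a 1.2-fold higher number from compound 3 to compound 4 (0.09 log units; within the scatter). For compound 4 the estimate is 220 nM, with an expected range from 100 nM to 480 nM.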

Compound 4, half-maximal inhibitory concentration: 290 nM
For compound 4 the middle estimate is 1.3-fold (0.12 log units) below the measured one; the range from low to high includes it.
By their numbers in this assay, from the lowest: compounds 3, 1, 4 and 2 (each within the scatter of the next, the first and the last beyond it).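

With 4-fluorophenyl held fixed, three groups on this carbonyl carbon can now be compared directly in this assay: the new group gives a 1.6-fold higher number from compound 3 to compound 4 (0.21 log units; within the scatter) and a 1.1-fold higher number from compound 1 to compound 4 (0.03 log units; within the scatter). Neither step leaves the scatter, and the same holds for the earlier step between tert-butyl and 4-methylpiperazin-1-yl, so this assay does not separate the three groups, even though 1-ethylpiperidin-4-yl carries one ring hetero atom where 4-methylpiperazin-1-yl carries two. Compound 4 also gives the first view of the other carbonyl carbon with 1-ethylpiperidin-4-yl held fixed: 4-fluorophenyl in place of isobutyl gives a 1.4-fold lower number from compound 2 to compound 4 (0.15 log units; within the scatter), which is also within the scatter, so that change is not resolved either.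

No measurement is available here that would explain why these numbers stay so close. From the compounds shown here alone, it remains open whether a carboxylic acid or a longer alkyl chain on the first carbonyl carbon, or an unsubstituted phenyl in place of 4-fluorophenyl, would move the number in this assay beyond the scatter.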